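Ring-to-chain change at the urea end of the series

The compounds below may be only part of what the source reports. "The series", "measured", "known", "first", "only" and "open" are said of these compounds alone.

Measured compounds:
compound 1 `COc1ncccc1C(=O)NCCC1CCN(S(=O)(=O)NC(=O)NC[C@@H]2C[C@@H]3CC[C@@H]2O3)CC1` gives 34%
compound 2 `COc1ncccc1C(=O)NCCC1CCN(S(=O)(=O)NC(=O)NC[C@H]2C[C@@H]3CC[C@@H]2O3)CC1` gives 14%
compound 3 `COc1ncccc1C(=O)NCCC1CCN(S(=O)(=O)NC(=O)NCC2CCCCO2)CC1` gives 12%

All three were run in a functional assay on the whole organism (blood) with Rattus norvegicus as the target, with stated times of 24 h and 1 h, at a dose of 5 mg/kg by the intraperitoneal route; a lower number here means a weaker effect, a higher number a stronger effect of the compound at the dose given. On the numbers shown, compound 3 sits together with compound 2, the two separated only by a gap within the scatter a number 2 percentage points lower from compound 2 to compound 3 (within the scatter), while compound 1 stands apart from compound 3 a number 22 percentage points lower from compound 1 to compound 3 (beyond the scatter). Compounds 1 and 2 differ only in configuration (the fact that compounds 1 and 2 differ only in the configuration as drawn), and that alone accounts for a number 20 percentage points lower from compound 1 to compound 2 (beyond the scatter).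

Compound 4 `CCOCCNC(=O)NS(=O)(=O)N1CCC(CCNC(=O)c2cccnc2OC)CC1` is not yet measured in this assay. It differs from compound 3 by ethoxymethyl in place of oxan-2-yl on a saturated chain carbon bound to an amide-type nitrogen. Among the measured compounds shown here, the steps that bear on this change are the two earlier replacements at the same place, on a saturated chain carbon bound to an amide-type nitrogen: the modest drop a number 22 percentage points lower from compound 1 to compound 3 (beyond the scatter) and the flat step a number 2 percentage points lower from compound 2 to compound 3 (within the scatter). Since compound 3 already carries the oxan-2-yl group and the exchange to ethoxymethyl is a further loosening at that position, no step beyond the scatter is expected in this assay; at most a small downward drift is anticipated, a number 1 percentage points lower from compound 3 to compound 4 (within the scatter). Compound 4 is therefore estimated at 11%, with a range from 2% to 26%.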

Compound 4, a percentage reported as activity, at one dose (the size of the read-out at that dose, not a potency): 7%
For compound 4 the middle estimate is 4 percentage points above the measured one; the range from low to high includes it.
By their numbers in this assay, from the lowest: compounds 4, 3 and 2 (each within the scatter of the next); then compound 1.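

In this assay, a ring at this place, on a saturated chain carbon bound to an amide-type nitrogen, proves unnecessary for holding the read-out at the level of the lower compounds: with ethoxymethyl in place of oxan-2-yl the step reads a number 5 percentage points lower from compound 3 to compound 4 (within the scatter), and against the group with two five-membered non-aromatic rings it reads a number 7 percentage points lower from compound 2 to compound 4 (within the scatter). The ring-free 2-ethoxyethyl group therefore falls in with compounds 2 and 3, and only compound 1 stands apart, as shown by a number 27 percentage points lower from compound 1 to compound 4 (beyond the scatter). The presence of a ring cannot by itself account for that gap, since the ring-bearing partner of compound 1 sits with the open chain: the fact that compounds 1 and 2 differ only in the configuration as drawn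

On these data alone, it remains open whether any other group at this place reaches or passes compound 1, for instance an amine, a carboxylic acid or a chain longer than 2-ethoxyethyl. With a single dose, the read-out gives only the size of the effect at that dose, so any difference in the strength of the effect at that dose among compounds 2, 3 and 4 stays unresolved.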